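A Basic Chain on the Other Ring Nitrogen

The source may hold more compounds than are shown below. What is called first, only, known or untested is meant among the compounds shown, and "the series" means these compounds.

Measured in a functional assay on K562 cells (Homo sapiens) for antiproliferative activity, read by MTT assay, with a stated time of 48 h; on this read-out lower numbers stand for stronger inhibition and higher numbers for weaker inhibition
- compound 1 `Cn1c(N)c(-c2nc3ccccc3[nH]2)c2nc(C#N)c(C#N)nc21` gives > 50000 nM
- compound 2 `CCN(CC)CCn1c(N)c(-c2nc3ccccc3[nH]2)c2nc(C#N)c(C#N)nc21` gives 2490 nM
- compound 3 `N#Cc1nc2c(-c3nc4ccccc4[nH]3)c(N)n(CCCN3CCCCC3)c2nc1C#N` gives 3460 nM

Compound 1 stands at the limit of > 50000 nM in this assay, at which 1 of the 3 values shown sits, which is a limit and not a number. Compound 4 `CN(C)CCCCn1c(-c2c(N)n(C)c3nc(C#N)c(C#N)nc23)nc2ccccc21` has not been measured, and it differs from compound 1 as follows: 4-(dimethylamino)butyl in place of hydrogen on an aromatic nitrogen. Within the data shown here, two measured steps bear on this: an at least 20-fold lower number from compound 1 to compound 2 (1.30 log units; beyond the scatter) and an at least 14-fold lower number from compound 1 to compound 3 (1.15 log units; beyond the scatter), both large. Each added a chain on a saturated chain carbon bound to an aromatic nitrogen, so they come from another place and guide only loosely. Between those two chains, a 1.4-fold higher number from compound 2 to compound 3 (0.14 log units; within the scatter). A similarly large step towards lower numbers is therefore expected in this assay. The expected step is an at least 16-fold lower number from compound 1 to compound 4 (1.22 log units; beyond the scatter). For compound 4 the estimate is 3000 nM, within an expected range from 700 nM to 15000 nM.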

Compound 4, half-maximal inhibitory concentration: 11300 nM
The estimate for compound 4 lay 3.8-fold (0.58 log units) below the measured number; the measured number falls inside the stated range.
By their numbers in this assay, from the lowest: compounds 2 and 3 (each within the scatter of the next); then compound 4. At a limit, above all of these: compound 1.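

Putting 4-(dimethylamino)butyl on an aromatic nitrogen of the five-membered aromatic ring with 2 nitrogen, which bears hydrogen in compounds 1, 2 and 3, gives an at least 4.4-fold lower number from compound 1 to compound 4 (0.64 log units; beyond the scatter) in this assay. A chain ending in an amine therefore lowers the number at this second place too, not only at the place changed in compounds 2 and 3. Compound 1 is a limit and not a number, so this step has no upper end: the limit of > 50000 nM in this assay, at which 1 of the 4 values shown sits.

Open, as far as these compounds go, is what a plain butyl chain without the amine, or a shorter chain ending in piperidine, would give on this nitrogen. That would tell whether the amine or the chain itself carries the step.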